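This account rests on a few compounds, and the source may have more. Where it says the series, first, only, none or still open, it means among the compounds named here.

Compound 2 `CC1(C)C[C@@H](CN([C@H](CCC(F)(F)F)C(N)=O)S(=O)(=O)c2ccc(Cl)cc2)O1` is one of two compounds with a value in an in vivo ADME assay on the whole organism for pharmacokinetics, with Rattus norvegicus as the target; on this read-out higher numbers stand for higher oral bioavailability and lower numbers for lower oral bioavailability. In this assay compound 2 gives < 5%, which is a limit of the assay rather than a number. Compound 1 `NC(=O)[C@@H](CCC(F)(F)F)N(CC1COC1)S(=O)(=O)c1ccc(Cl)cc1` differs from compound 2 in one place. In this assay compound 1 gives < 5%, also a limit. The step that the two limits leave unreadable from compound 1 to compound 2 therefore cannot be read; the limit of < 5% in this assay, at which 2 of the 2 values shown sit, shows that both measured values sit at that limit. Compound 3 `NC(=O)[C@@H](CCC(F)(F)F)N(C[C@@H]1CCO1)S(=O)(=O)c1ccc(Cl)cc1` has not yet been measured in this assay. It differs from compound 2 by oxetan-2-yl in place of 4,4-dimethyloxetan-2-yl on a saturated chain carbon bound to a sulfonamide nitrogen. Going by the values given here, no measured step bears directly on this change; the only measured step, from compound 1 to compound 2, is unreadable and concerns a different substituent on the same saturated chain carbon. With both measured values sitting at the limit, compound 3 is expected to remain near it, and the expected step that the limit leaves unreadable from compound 2 to compound 3 is none beyond the scatter. Compound 3 is estimated at 3%, in the range 0% to 12%, and is most likely to be reported again only as a limit.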

Compound 3, oral bioavailability: < 5%
Compound 3: a limit, no number (the forecaster's own chance of this, stated with the estimate: 80%); the middle value is on the limit's open side.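

In this assay compound 3 gives < 5%, which is a limit of the assay and not a number. No step among compound 1, compound 2 and compound 3 can therefore be read: the limit of < 5% in this assay, at which 3 of the 3 values shown sit.

The compounds shown leave open how these three compare with one another, and whether any substituent at this place would give a readable number.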